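Swapping the benzyl halogens on a sialic acid mimic

A few compounds are considered here, and "the series" means these few. Any claim that something is new, unique, unknown or untested is made for them only; others in the source may bear on it.

Compound 1 `CO[C@]1(C(=O)O)C[C@H](O)[C@@H](NC(C)=O)[C@H]([C@@H](O)[C@H](O)CNC(=O)c2ccccc2)O1`: 137000 nM
Compound 2 `CC(=O)N[C@H]1[C@H]([C@@H](O)[C@H](O)CNC(=O)c2ccc(Cl)cc2)O[C@@](OCc2ccc(Cl)cc2)(C(=O)O)C[C@@H]1O`: 15000 nM
Compound 3 `CC(=O)N[C@H]1[C@H]([C@@H](O)[C@H](O)CNC(=O)c2ccc(Cl)cc2)O[C@@](OCc2c(F)c(F)c(F)c(F)c2F)(C(=O)O)C[C@@H]1O`: 6100 nM

Of the compounds shown here, three share a core and have been measured in an in vitro assay on cells for binding affinity to myelin-associated glycoprotein (Mus musculus), read by surface plasmon resonance; a higher number here means weaker binding, a lower number tighter binding. Compound 3 gives the lowest number of the three, ahead of compound 2 by the step of a 2.5-fold lower number from compound 2 to compound 3 (0.39 log units; beyond the scatter), and far ahead of compound 1. Compound 4 `CC(=O)N[C@H]1[C@H]([C@@H](O)[C@H](O)CNC(=O)c2ccc(Cl)cc2)O[C@@](OCc2cccc(Cl)c2Cl)(C(=O)O)C[C@@H]1O` is not yet measured; it differs from compound 3 by 2,3-dichlorophenyl in place of 2,3,4,5,6-pentafluorophenyl on a saturated chain carbon bound to an oxygen on a saturated carbon. Among the measured compounds shown here, only one measured step bears on this spot: from compound 2 to compound 3, a 2.5-fold lower number from compound 2 to compound 3 (0.39 log units; beyond the scatter), a modest change. The new ring carries fewer halogens than the leaving one, so a small move back toward compound 2 is expected, a 1.5-fold higher number from compound 3 to compound 4 (0.17 log units; within the scatter). Compound 4 is therefore estimated at 9000 nM, with a range of 4000 nM to 20000 nM.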

Compound 4, dissociation constant: 4300 nM
Estimate against measurement, compound 4: 2.1-fold (0.32 log units) above; the range from low to high includes it.
By their numbers in this assay, from the lowest: compounds 4 and 3 (each within the scatter of the next); then compound 2; then compound 1.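

In this assay, the 2,3-dichlorophenyl ring, with fewer halogens, does as well as the 2,3,4,5,6-pentafluorophenyl ring, with a 1.4-fold lower number from compound 3 to compound 4 (0.15 log units; within the scatter), so more halogens on this ring do not by themselves give a lower number. Both rings still beat the 4-chlorophenyl ring of compound 2, and for the new ring this is a 3.5-fold lower number from compound 2 to compound 4 (0.54 log units; beyond the scatter). Nothing at hand explains these results. As far as these compounds go, how an amine on this ring, or a longer chain joining the ring to the oxygen, would read remains open.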